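A few compounds are considered here, and "the series" means these few. Any claim that something is new, unique, unknown or untested is made for them only; others in the source may bear on it.

Working notes on the series. Two compounds of this set have numbers in an assay on a protein complex for binding affinity to integrin alpha-5/beta-1 (Homo sapiens), read by ELISA, with a stated time of 1 h; on this read-out higher numbers stand for weaker inhibition and lower numbers for stronger inhibition. Compound 1 `N=C(N)Nc1cccc(C(=O)NCC(=O)N[C@@H](CC(=O)O)C(=O)Nc2cccc3ccccc23)c1` gives 22 nM in this assay. Compound 2 `C[C@H](NC(=O)[C@H](CC(=O)O)NC(=O)CNC(=O)c1cccc(NC(=N)N)c1)c1ccccc1` gives 20 nM in this assay. Within the data shown here, the one step measured so far, a 1.1-fold lower number from compound 1 to compound 2 (0.04 log units; within the scatter), sits at the amide-type nitrogen and does not separate the two compounds: compound 2 and compound 1 stand within the scatter of each other, and neither can be called the stronger binder on these numbers.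

Compound 3 `COc1ccc(CNC(=O)[C@H](CC(=O)O)NC(=O)CNC(=O)c2cccc(NC(=N)N)c2)cc1` is the next member. It differs from compound 2 in one place: 4-methoxybenzyl in place of 1-phenylethyl on an amide-type nitrogen. Among the measured compounds shown here, the only measured step that bears on this position is a 1.1-fold lower number from compound 1 to compound 2 (0.04 log units; within the scatter), where exchanging one hydrocarbon group for another at the same nitrogen left the number essentially unchanged. Nothing measured here speaks for a shift in either direction on adding a methoxy-bearing benzyl group at this nitrogen, so no step beyond the scatter is expected in this assay. Compound 3 is expected to give about 25 nM in this assay, within a range of 10 nM to 65 nM, which means an estimated step of a 1.3-fold higher number from compound 2 to compound 3 (0.10 log units; within the scatter).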

Compound 3, half-maximal inhibitory concentration: 40 nM
Compound 3: middle estimate off by 1.6-fold (0.20 log units), on the low side, within the range that was stated.
By their numbers in this assay, from the lowest: compounds 2, 1 and 3 (each within the scatter of the next).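

In this assay, among these compounds, the amide-type nitrogen now carries a group with a hydrogen-bond acceptor, where the earlier compounds offered only the hydrocarbon groups naphthalen-1-yl and 1-phenylethyl, and neither a 2.0-fold higher number from compound 2 to compound 3 (0.30 log units; within the scatter) nor a 1.8-fold higher number from compound 1 to compound 3 (0.26 log units; within the scatter) separates compound 3 from the earlier two. Across these three groups, which include a fused aromatic group, a branched group with a defined stereocentre and an unbranched benzyl group bearing a methoxy, no pair at this nitrogen stands apart on these numbers. No supporting data are available here to explain this result.

The change from 1-phenylethyl to 4-methoxybenzyl removes the defined stereocentre and adds the oxygen in a single step, so these compounds cannot show what each alteration contributes alone. Also open, as far as these compounds go, are a plain benzyl group, which would separate those two alterations, and groups of another kind at this nitrogen, such as a benzyl group bearing a carboxylic acid or an amine, or a longer chain between the nitrogen and the aromatic ring.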